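This account rests on a few compounds, and the source may have more. Where it says the series, first, only, none or still open, it means among the compounds named here.

Of the compounds shown here, two have so far been measured in a functional assay on B16-F10 cells (Mus musculus) for inhibition, read by MTT assay, with a stated time of 72 h; a lower number here means a stronger inhibitor, a higher number a weaker inhibitor. Compound 1 `C#CCSc1nc(Nc2cccc(Cl)c2)c(C#N)c(-c2ccccc2)n1` gives 10500 nM in this assay. Compound 2 `N#Cc1c(Nc2cccc(C(F)(F)F)c2)nc(SCc2cn(Cc3ccccc3Cl)nn2)nc1-c1ccccc1` gives 3710 nM in this assay, the lower of the two numbers; the gap to compound 1 lies beyond the usual scatter, so compound 2 is the stronger inhibitor of the pair so far. Within the data shown here, no two measured compounds differ in only one place, so no single step has yet been read from the data.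

Compound 3 `N#Cc1c(Nc2cccc([N+](=O)[O-])c2)nc(SCc2cn(Cc3ccccc3Cl)nn2)nc1-c1ccccc1` has not yet been measured. It keeps the shared core and the substitution pattern of compound 2 and differs in one place: nitro in place of trifluoromethyl on an aromatic carbon. Among the measured compounds shown here, no measured pair shows the effect of this change, so there is nothing to lean on beyond the value of compound 2 itself. The expected step in this assay is small, a 1.1-fold higher number from compound 2 to compound 3 (0.03 log units; within the scatter), and not clearly beyond the scatter in either direction. Compound 3 is therefore expected to give about 4000 nM in this assay, within a range of 1500 nM to 11000 nM.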

Compound 3, half-maximal inhibitory concentration: 17200 nM
Compound 3: the middle estimate sits 4.3-fold (0.63 log units) below what was measured; the whole stated range lies below it.
By their numbers in this assay, from the lowest: compound 2; then compounds 1 and 3 (each within the scatter of the next).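

Nitro in place of trifluoromethyl gives the first single change that can be read in this series: in this assay it is (a 4.6-fold higher number from compound 2 to compound 3 (0.67 log units; beyond the scatter)), a step beyond the scatter. This shows that the aromatic carbon of the 3-(trifluoromethyl)phenyl group is not indifferent to what it carries, as the rest of the structure stays the same and the nitro compound is the weaker inhibitor of this pair. The result rests on one pair, and no measurement shown accounts for the step.

From the compounds shown here alone, it remains open whether trifluoromethyl is specifically favourable here or nitro specifically unfavourable, and an amine, a carboxylic acid or a methoxy group on the same aromatic carbon would help separate these two readings. Going by these compounds, it also remains open whether the same exchange would give a step of similar size with a different group on the sulfur, such as the shorter propargyl chain, since this change has been read only with the group that compound 2 and compound 3 share.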